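One ring swap on a shared core

A few compounds are considered here, and "the series" means these few. Any claim that something is new, unique, unknown or untested is made for them only; others in the source may bear on it.

Of the compounds shown here, three that share a core have been measured in a functional assay for activation of Alpha-1B adrenergic receptor (Homo sapiens), read by calcium flux; on this read-out lower numbers stand for an effect already at smaller amounts and higher numbers for an effect only at larger amounts of compound. Compound 1 `CCN(CC)C(=O)c1ccccc1OCC1=NCCN1` gives only a limit of the assay, not a number: < 5020 nM, (the limit of < 5020 nM in this assay, at which 1 of the 3 values shown sits). Compound 2 `Cc1cccc(-c2ccccc2OCC2=NCCN2)n1` likewise gives only a limit in this assay: < 100000 nM, (the limit of < 100000 nM in this assay, at which 1 of the 3 values shown sits). For the measured compounds named here, compound 3 `c1ccc(-c2ccsc2)c(OCC2=NCCN2)c1` is the one compound with a real number; in this assay compound 3 gives 15.9 nM. It stands alone as the only measured value among the three, and no ranking of compound 1 or compound 2 against it follows from what is shown.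

Compound 4 `Cc1cnsc1-c1ccccc1OCC1=NCCN1` has not yet been measured. It differs from compound 3 in one place: 4-methyl-1,2-thiazol-5-yl in place of thiophen-3-yl on an aromatic carbon. Going by the values given here, no measured pair in this set makes such a change, so no measured step can guide the size of the effect. The exchange is expected to cost little, a step of a 2.5-fold higher number from compound 3 to compound 4 (0.40 log units; beyond the scatter) that may stay within the usual scatter. Compound 4 is expected to give about 40 nM in this assay, within 10 nM to 160 nM.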

Compound 4, half-maximal effective concentration: < 100000 nM
Compound 4: no number, only a limit; the forecaster's own chance of this, stated with the estimate: 5%; the middle value does not contradict the limit.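

For the compounds shown here, compound 4 gives only a limit of the assay (< 100000 nM), not a number, so no step from compound 3 to compound 4 can be read. The compounds shown leave open how compound 4 really compares with compound 3 once the thiophen-3-yl is exchanged for 4-methyl-1,2-thiazol-5-yl.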